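The source may hold more compounds than are shown below. What is called first, only, known or untested is meant among the compounds shown, and "the series" means these compounds.

In a functional assay on Raji cells (Homo sapiens) for antiproliferative activity, read by MTT assay, with a stated time of 72 h (on this read-out higher numbers stand for weaker inhibition and lower numbers for stronger inhibition), compound 1 (`Cc1ccc(CN2CCC(c3noc(CN(C)c4ncc(/C=C/C(=O)NO)cn4)n3)CC2)cc1`) stands at 293 nM and compound 2 (`CN(Cc1nc(C2CCN(Cc3ccccc3)CC2)no1)c1ncc(C(=O)NO)cn1`) at 27.6 nM while compound 3 (`Cc1cccc(CN2CCC(c3noc(CN(C)c4ncc(C(=O)NO)cn4)n3)CC2)c1`) reads 47.3 nM and so lies within the scatter of compound 2 and well under compound 1. Compound 4 (`CN(Cc1nc(C2CCN(Cc3ccc(C#N)cc3)CC2)no1)c1ncc(C(=O)NO)cn1`) has 4-cyanophenyl in place of 3-methylphenyl on a saturated chain carbon bound to an amine nitrogen in a ring. Among the measured compounds shown here, the one measured step on that aromatic ring is a 1.7-fold higher number from compound 2 to compound 3 (0.23 log units; within the scatter) and is small. For the measured compounds named here, no measured compound holds a nitrile, so the data give no direct size for this change. Hence the estimate in this assay is a 1.2-fold lower number from compound 3 to compound 4 (0.07 log units; within the scatter) and no step beyond the scatter is expected. For compound 4 the estimated value is 40 nM with an expected range from 15 nM to 110 nM as the working figure.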

Compound 4, half-maximal inhibitory concentration: 117 nM
For compound 4 the middle estimate is 2.9-fold (0.47 log units) below the measured one, outside the stated range (above it).
By their numbers in this assay, from the lowest: compounds 2 and 3 (each within the scatter of the next); then compound 4; then compound 1.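

In this assay, this benzyl ring proves sensitive to substitution: adding the nitrile gives a 4.2-fold higher number from compound 2 to compound 4 (0.63 log units; beyond the scatter), beyond the scatter, whereas the methyl step from compound 2 to compound 3 stayed within it. The change from 3-methylbenzyl to 4-cyanobenzyl gives a 2.5-fold higher number from compound 3 to compound 4 (0.39 log units; beyond the scatter), but it alters both the group and its ring position, so this step cannot separate the two. Nothing available explains these higher numbers. Comparing 3-cyanobenzyl with 4-cyanobenzyl would test the ring position directly. Going by these compounds, whether an amine or carboxylic acid on this ring behaves like the nitrile remains open.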